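A few compounds are considered here, and "the series" means these few. Any claim that something is new, unique, unknown or untested is made for them only; others in the source may bear on it.

In a functional assay on MCF7 cells (Homo sapiens) for inhibition, read by CCK-8 assay, with a stated time of 48 h (a lower number here means a stronger inhibitor of growth, a higher number a weaker inhibitor of growth), compound 1 `O=C(CCCSC[C@H](NC(=O)OCc1ccccc1)C(=O)Nc1ccccc1)NO` gives 4700 nM and compound 2 `O=C(CCCSC[C@H](NC(=O)OCc1ccccc1)C(=O)Nc1cccc2ccccc12)NO` gives 4900 nM, which places the two within the scatter of each other. Compound 3 `O=C(CCCSC[C@H](NC(=O)c1ccccc1)C(=O)Nc1ccccc1)NO` keeps the core of compound 1 but alters one group: phenyl in place of benzyloxy on a carbonyl carbon. Going by the values given here, the only measured step, a 1.0-fold higher number from compound 1 to compound 2 (0.02 log units; within the scatter), lies within the scatter, but it is a change on an amide-type nitrogen, not on the carbonyl carbon, so it offers only weak guidance. No step beyond the scatter is therefore expected in this assay, and the estimated step is a 1.1-fold higher number from compound 1 to compound 3 (0.03 log units; within the scatter). For compound 3 the expected value is 5000 nM, with an estimated range of 2000 nM to 12000 nM.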

Compound 3, concentration for 50% growth inhibition: 3700 nM
Compound 3: middle estimate off by 1.4-fold (0.13 log units), on the high side, and the stated range covers the measured number.
By their numbers in this assay, from the lowest: compounds 3, 1 and 2 (each within the scatter of the next).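

In this assay, phenyl in place of benzyloxy on the carbonyl carbon gives a 1.3-fold lower number from compound 1 to compound 3 (0.10 log units; within the scatter), so shortening benzyloxycarbonyl to benzoyl leaves growth inhibition unchanged within the scatter. Going by these compounds alone, the earlier step concerned only the group on a different amide-type nitrogen, so this is the first sign that this second place also accepts a change. No measurement shown here offers an explanation for this result.

From the compounds shown here alone, whether an amine, a carboxylic acid or a longer chain on this carbonyl carbon would move the number beyond the scatter remains open.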